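A Second Hydroxy on Compound 1

The source may report more compounds than this note shows. Statements on the series, on what has been measured and on what is new or still open speak of the compounds shown alone.

Three compounds share one core and differ in a single group on an aromatic carbon: compound 1 `N[C@@H](CCC(=O)NNc1cccc(O)c1)C(=O)O`, compound 2 `Cc1cccc(NNC(=O)CC[C@H](N)C(=O)O)c1` and compound 3 `N[C@@H](CCC(=O)NNc1cccc(F)c1)C(=O)O`. In a functional assay, read by spectrophotometry, with a stated time of 30 min (on this read-out higher numbers stand for weaker inhibition and lower numbers for stronger inhibition), compound 1 gives 10.7 ug/mL, compound 2 gives 10.1 ug/mL and compound 3 gives 11.4 ug/mL. Compound 1 therefore cannot be told apart from the other two, since all three values lie within the scatter of one another.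

The unmeasured compound 4 `N[C@@H](CCC(=O)NNc1cc(O)cc(O)c1)C(=O)O` keeps the hydroxy of compound 1 and gains another: hydroxy in place of hydrogen on an aromatic carbon. The new hydroxy stands meta to a hydroxy group and meta to a large group.

The measured steps bear on this only indirectly. Methyl in place of hydroxy gives a 1.1-fold lower number from compound 1 to compound 2 (0.03 log units; within the scatter), fluoro in place of hydroxy gives a 1.1-fold higher number from compound 1 to compound 3 (0.03 log units; within the scatter), and fluoro in place of methyl gives a 1.1-fold higher number from compound 2 to compound 3 (0.05 log units; within the scatter). Going by the values given here, all three stay within the scatter, but none of them puts a hydroxy in place of hydrogen, so the data hold no direct precedent. Taking the value of compound 1, 10.7 ug/mL, as the anchor, no change beyond the scatter is expected in this assay, and neither direction is favoured. The expected step is a 1.1-fold lower number from compound 1 to compound 4 (0.03 log units; within the scatter). For compound 4 the estimated value is 10 ug/mL, with an expected range from 5 ug/mL to 20 ug/mL.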

Compound 4, half-maximal inhibitory concentration: 317 ug/mL
For compound 4 the middle estimate is 32-fold (1.50 log units) below the measured one; the whole stated range lies below it.
By their numbers in this assay, from the lowest: compounds 2, 1 and 3 (each within the scatter of the next); then compound 4.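

In this assay, hydroxy in place of hydrogen on this aromatic carbon, meta to a hydroxy group and meta to a large group, gives much weaker inhibition (a 30-fold higher number from compound 1 to compound 4 (1.47 log units; beyond the scatter)). The earlier compounds shown here varied only the group at one aromatic carbon, swapping among hydroxy, methyl and fluoro, and every one of those steps stayed within the scatter. Going by these compounds alone, this step is the first beyond the scatter, so the aromatic carbon that carries hydrogen in compound 1 is not a place where a change goes unnoticed, even though the swaps at the other carbon gave no sign of this. Nothing available explains the loss of inhibition.

The compounds shown leave open whether the effect belongs to hydroxy itself or would also appear with another group on this carbon, such as an amine, a methoxy group or a carboxylic acid. They also leave open whether it needs the first hydroxy, a question that the same new hydroxy paired with methyl or fluoro in the place of that first group would address.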